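The source may report more compounds than this note shows. Statements on the series, on what has been measured and on what is new or still open speak of the compounds shown alone.

Measured so far in a functional assay on the whole organism (strain Sprague-Dawley CD) for inhibition, with Rattus norvegicus as the target, read by paw edema, at a dose of 30 mg/kg by the intraperitoneal route; on this read-out lower numbers stand for a weaker effect and higher numbers for a stronger effect at the one dose given:
- compound 1 `CCOC(=O)C(=O)Nc1ccc(NC(=O)C(=O)OCC)c(=O)cc1` gives 84%
- compound 2 `CC(C)OC(=O)C(=O)Nc1cccccc1=O` gives 96%
- compound 3 `O=C(O)C(=O)Nc1cccccc1=O` gives 77%; 75% (2 entries)

Compound 2 stands highest of the two single numbers; the gap down to compound 1 lies beyond the scatter. Compound 3 is recorded twice and its two entries agree closely (the several entries of compound 3 in this assay, 77%; 75% (2 entries)); both sit under the value of compound 2.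

Compound 4 `O=C(O)COC(=O)C(=O)Nc1cccccc1=O` has not been measured. It differs from compound 2 in one place (carboxymethyl in place of isopropyl on an oxygen next to a carbonyl group). For the measured compounds named here, no measured pair shows this change, so its size is open. The nearest pointer is compound 3, whose values in this assay fall below compound 2, and compound 1, which also sits below compound 2.

The step from compound 2 in this assay is expected as a number 14 percentage points lower from compound 2 to compound 4 (beyond the scatter), downward and somewhat beyond the scatter. Compound 4 is estimated at 82%, with a range from 65% to 95%.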

Compound 4, a percentage reported as inhibition, in the whole organism at one dose (the size of the read-out at that dose, not a potency): 93%
Beside the measured number, compound 4's estimate is 11 percentage points below it; the range from low to high includes it.
By their numbers in this assay, from the lowest: compounds 1, 4 and 2 (each within the scatter of the next, the first and the last beyond it).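

In this assay, the step for carboxymethyl in place of isopropyl on an oxygen next to a carbonyl group reads a number 3 percentage points lower from compound 2 to compound 4 (within the scatter). For the compounds shown here, this is the first measured change at this position, and it shows that the position accepts a group carrying a hydrogen-bond donor and a hydrogen-bond acceptor, neither of which isopropyl has, without a step beyond the scatter. Nothing at hand gives a cause for the size of this step.

The read-out gives the size of the effect at one dose, so any difference in potency between these two compounds remains unresolved. Also open, from the compounds shown here alone, is whether an amine at the end of the chain, or a longer chain ending in a carboxylic acid, on this same oxygen would keep the effect in this range.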